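Swapping an Ester for an Alcohol on the Amide Chain

The source may hold more compounds than are shown below. What is called first, only, known or untested is meant among the compounds shown, and "the series" means these compounds.

Values in a functional assay on HepG2 cells (Homo sapiens) for antiproliferative activity, read by MTT assay, with a stated time of 48 h; a higher number here means a weaker inhibitor, a lower number a stronger inhibitor:
- Compound 1 `C#CC(C)OC(=O)c1ccc(C(CC)(CC)c2ccc(OCCC(O)(CC)CC)c(C)c2)n1CC`: > 50000 nM, a limit
- Compound 2 `CCOC(=O)CN(C)C(=O)c1ccc(C(CC)(CC)c2ccc(OCCC(O)(CC)CC)c(C)c2)n1CC`: 25300 nM

Among the compounds with values here, compound 2 holds the only actual number here, since compound 1 sits at a limit. Compound 3 `CCn1c(C(=O)N(C)CCO)ccc1C(CC)(CC)c1ccc(OCCC(O)(CC)CC)c(C)c1` carries hydroxymethyl in place of ethoxycarbonyl on a saturated chain carbon bound to an amide-type nitrogen, (hydroxymethyl in place of ethoxycarbonyl on a saturated chain carbon bound to an amide-type nitrogen). Within the data shown here, the one measured step, an at least 1.9-fold lower number from compound 1 to compound 2 (0.29 log units; that floor lies within the scatter), replaces the whole group on a carbonyl carbon and gives only a floor, so it sets no direction for this change. The expected change is none beyond the scatter, a 1.2-fold higher number from compound 2 to compound 3 (0.07 log units; within the scatter). Compound 3 is estimated at 30000 nM, with an expected range from 14000 nM to 50000 nM.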

Compound 3, half-maximal inhibitory concentration: 510 nM
For compound 3 the middle estimate is 59-fold (1.77 log units) above the measured one; measured number outside the range, below it.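

In this assay, the chain on the amide nitrogen proves to be a sensitive place, which compound 1 and compound 2 could not show: hydroxymethyl in place of ethoxycarbonyl gives a 50-fold lower number from compound 2 to compound 3 (1.70 log units; beyond the scatter) and so a large step from one small change. Replacing the whole group on the carbonyl carbon gives an at least 98-fold lower number from compound 1 to compound 3 (1.99 log units; beyond the scatter) as a floor only: the limit of > 50000 nM in this assay, at which 1 of the 3 values shown sits.

Going by these compounds, it stays open whether the hydroxyl itself matters or only the loss of the ethoxycarbonyl, and how a carboxylic acid, an amine or a longer hydroxyalkyl chain would read here.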